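The source may report more compounds than this note shows. Statements on the series, on what has been measured and on what is new or still open speak of the compounds shown alone.

Of the compounds shown here, three that share one core have been measured in a functional assay on MGC-803 cells (Homo sapiens) for antiproliferative activity, read by MTT assay, with a stated time of 48 h; on this read-out lower numbers stand for stronger inhibition and higher numbers for weaker inhibition. Compound 1, `O=C(Nc1cccc(CNc2nccnc2Cl)c1)NC1CCCC1`, gives 23400 nM in this assay. Compound 2, `O=C(Nc1cccc(CNc2nccnc2Cl)c1)Nc1cccc(C(F)(F)F)c1`, gives 7290 nM in this assay. Compound 3, `O=C(Nc1cccc(CNc2nccnc2Cl)c1)Nc1cccc2ccccc12`, gives 32700 nM in this assay. Among these three numbers, compound 1 stands second highest; its value and that of compound 3 lie within the scatter of each other, so no order between them can be read, whereas compound 2 gives a number clearly lower than compound 1, a gap that lies beyond the scatter.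

A fourth compound, compound 4, `O=C(Nc1cccc(CNc2nccnc2Cl)c1)Nc1ccc(Cl)c(Cl)c1`, has not yet been measured in this assay. It differs from compound 1 in one place: 3,4-dichlorophenyl in place of cyclopentyl on an amide-type nitrogen. No measured pair in this set reports exactly this change, so the expectation for compound 4 rests on the compounds shown. Compound 2, which carries a substituted six-membered aromatic ring on the same amide-type nitrogen, gives 7290 nM, and compound 4 is estimated to fall near that number rather than near compound 1. The step from compound 1 to compound 4 is therefore expected to run toward a lower number, a 2.9-fold lower number from compound 1 to compound 4 (0.47 log units; beyond the scatter), beyond the scatter. For compound 4 the estimated value in this assay is 8000 nM, with a range from 2500 nM to 25000 nM.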

Compound 4, half-maximal inhibitory concentration: 4970 nM
For compound 4 the middle estimate is 1.6-fold (0.21 log units) above the measured one; the range from low to high includes it.
By their numbers in this assay, from the lowest: compounds 4 and 2 (each within the scatter of the next); then compounds 1 and 3 (each within the scatter of the next).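

In this assay, placing 3,4-dichlorophenyl in place of cyclopentyl on the amide-type nitrogen gives the first single-change step read at this position, a 4.7-fold lower number from compound 1 to compound 4 (0.67 log units; beyond the scatter), which shows that the number responds to the group carried there. Compound 2 gives 7290 nM and compound 4 gives 4970 nM, values within the scatter of each other, so two differently substituted six-membered aromatic rings cannot be told apart here, while compound 3 goes against any simple rule that an aromatic group on this nitrogen lowers the number, since compound 3 gives 32700 nM, within the scatter of compound 1. Nothing in the data shown accounts for the step from the cyclopentyl group to the 3,4-dichlorophenyl group.

The compounds shown leave open whether both chlorines are needed, since an unsubstituted phenyl group or a phenyl group with a single chlorine does not appear among them. They also leave open how this nitrogen would tolerate a phenyl ring carrying a carboxylic acid or an amine, or a longer chain such as hexyl in place of the ring.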